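Removing a para chloro group on a chlorophenyl ring

The source may hold more compounds than are shown below. What is called first, only, known or untested is meant among the compounds shown, and "the series" means these compounds.

Of the compounds shown here, three have been tested in a functional assay on HCT-116 cells (Homo sapiens) for cytotoxicity, read by MTT assay, with a stated time of 48 h; on this read-out lower numbers stand for stronger inhibition and higher numbers for weaker inhibition. Compound 1 `Cc1nn(-c2ccccc2)c2nc(C(=O)N3NC(=O)/C(=C/c4ccc(Cl)cc4)N=C3c3ccccc3)[nH]c(=O)c12` gives 28.1 nM, and compound 2 `Cc1nn(-c2ccccc2)c2nc(C(=O)N3NC(=O)/C(=C/c4ccccc4)N=C3c3ccccc3)[nH]c(=O)c12` gives 14.7 nM. The two differ by one change, (hydrogen in place of chloro on an aromatic carbon), and the step is a 1.9-fold lower number from compound 1 to compound 2 (0.28 log units; within the scatter). Compound 3 `COc1ccc(/C=C2\N=C(c3ccc(Cl)cc3)N(C(=O)c3nc4c(c(C)nn4-c4ccccc4)c(=O)[nH]3)NC2=O)cc1` gives 12.9 nM; how its core differs from that of compound 1 is not broken down here. Compound 4 `COc1ccc(/C=C2\N=C(c3ccccc3)N(C(=O)c3nc4c(c(C)nn4-c4ccccc4)c(=O)[nH]3)NC2=O)cc1` has not yet been measured. It differs from compound 3 by hydrogen in place of chloro on an aromatic carbon, the same change as between compound 1 and compound 2, at the same kind of place. Because that earlier step was a 1.9-fold lower number from compound 1 to compound 2 (0.28 log units; within the scatter), a step of similar size is expected here, so the expected step is a 1.6-fold lower number from compound 3 to compound 4 (0.21 log units; within the scatter). Compound 4 is therefore estimated at 8 nM, within a range from 4 nM to 20 nM.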

Compound 4, half-maximal inhibitory concentration: 52.1 nM
Beside the measured number, compound 4's estimate is 6.5-fold (0.81 log units) below it; the whole stated range lies below it.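

The change from chloro to hydrogen did not carry over between these two cores: the same change on two cores in this assay, a 1.9-fold lower number (0.28 log units; within the scatter) from compound 1 to compound 2 and a 4.0-fold higher number (0.61 log units; beyond the scatter) from compound 3 to compound 4, 7.7-fold (0.89 log units) apart, beyond the scatter of two such steps. Its effect here depends on the surrounding molecule, as a 4.0-fold higher number from compound 3 to compound 4 (0.61 log units; beyond the scatter) shows, but two pairs give no rule for the series and no explanation for the mismatch. On the ring where methoxy is exchanged, methoxy in place of hydrogen gives a 3.5-fold higher number from compound 2 to compound 4 (0.55 log units; beyond the scatter), and methoxy in place of chloro gives a 1.9-fold higher number from compound 1 to compound 4 (0.27 log units; within the scatter).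

Going by these compounds, it remains open whether a fluoro group, a bromo group or an amine in the chloro position would follow the pattern of either core. A third pair on another core would also be needed to show which of the two steps is more typical.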